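Rearranging a bicyclic group in a factor X series

The source may hold more compounds than are shown below. What is called first, only, known or untested is meant among the compounds shown, and "the series" means these compounds.

Measured compounds in an assay on isolated protein for inhibition of coagulation factor X (Oryctolagus cuniculus), tested at 1 uM; on this read-out higher numbers stand for more inhibition at the one concentration tested (going by the name of the read-out) and lower numbers for less inhibition:
Compound 1 `O=C1[C@@H](NS(=O)(=O)c2cc3ccc(Cl)nc3s2)CCN1Cc1cc2cc[nH]cc-2n1`: 50%
Compound 2 `O=C1[C@@H](NS(=O)(=O)c2ccc(-c3ccon3)s2)CCN1Cc1cc2cc[nH]cc-2n1`: 49%
Compound 3 `O=C1[C@@H](NS(=O)(=O)c2nc3cc(Cl)ccc3[nH]2)CCN1Cc1cc2cc[nH]cc-2n1`: 21%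

Compound 3 stands lowest of the three; the step of a number 29 percentage points lower from compound 1 to compound 3 (beyond the scatter) and the step of a number 28 percentage points lower from compound 2 to compound 3 (beyond the scatter) both lie beyond the scatter, whereas a number 1 percentage points lower from compound 1 to compound 2 (within the scatter) does not. Compound 4 `O=C1[C@@H](NS(=O)(=O)c2nc3cc(Cl)ccc3[nH]2)CCN1Cc1cc2c[nH]ccc-2n1` differs from compound 3 by a group of 9 heavy atoms (7 carbon, 2 nitrogen; one five-membered aromatic ring with 1 hetero atom, one six-membered aromatic ring with 1 hetero atom) in place of a group of 9 heavy atoms (7 carbon, 2 nitrogen; one five-membered aromatic ring with 1 hetero atom, one six-membered aromatic ring with 1 hetero atom), on a saturated chain carbon bound to an amide-type nitrogen in a ring. Every measured step concerns the group on the sulfonyl sulfur, so none bears on this change, and the data give no basis for expecting a step in either direction. The estimate for compound 4 is therefore 21%, within 5% to 42%, meaning an expected step of no change at the digits printed from compound 3 to compound 4 (within the scatter) that may not exceed the scatter.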

Compound 4, a percentage reported as inhibition, at one concentration (the size of the read-out at that concentration, not a potency): 31%
Compound 4: the middle estimate sits 10 percentage points below what was measured; low and high end bracket the measured number.
By their numbers in this assay, from the lowest: compounds 3 and 4 (each within the scatter of the next); then compounds 2 and 1 (each within the scatter of the next).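

This is the only step shown at this position, on a saturated chain carbon bound to an amide-type nitrogen in a ring. With the same atoms joined differently and 5-chloro-1H-benzimidazol-2-yl kept on the sulfonyl sulfur, this assay gives a number 10 percentage points higher from compound 3 to compound 4 (within the scatter), so this change does not separate the two compounds on this read-out. No available evidence bears on this result.

From the compounds shown here alone, it remains open whether the same change would read alike with 5-(1,2-oxazol-3-yl)thiophen-2-yl on the sulfonyl sulfur. Also open, going by these compounds, is what an amine on the bicyclic group would do at this position.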